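The source may hold more compounds than are shown below. What is called first, only, known or untested is meant among the compounds shown, and "the series" means these compounds.

Measured compounds:
- compound 1, `O=C(Cn1cc(-c2ccccc2Cl)nn1)Nc1nccs1`, gives 60 nM
- compound 2, `O=C(Cn1cc(-c2ccncc2)nn1)Nc1nc2ccccc2s1`, gives 50 nM
- compound 3, `CCOC(=O)c1sc(NC(=O)Cn2cc(-c3ccc(OC)cc3)nn2)nc1C`, gives 2330 nM

All three numbers come from a functional assay on BMDM cells (Mus musculus, strain C57BL/6) for inhibition, with a stated time of 2 days; on this read-out higher numbers stand for weaker inhibition and lower numbers for stronger inhibition. On these numbers compound 2 stands lowest of the three. Its nearest neighbour is compound 1, whose number lies within the usual scatter of compound 2, so no order between the two can be read. Compound 3 stands far away, beyond the scatter, with a markedly higher number than compound 2; compound 3 also carries a different core from compounds 1 and 2, so its gap to compound 2 is not a single-point step and is not broken down further here.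

The next compound, compound 4, `Nc1cccc(-c2cn(CC(=O)Nc3nc4ccccc4s3)nn2)c1`, is derived from compound 2 by one change: 3-aminophenyl in place of pyridin-4-yl on an aromatic carbon. The rest of the structure of compound 2, including its core and the bicyclic amide side, is kept.

For the measured compounds named here, no measured pair with a single change is available in this assay, so the size of the step cannot be taken from the data. The aryl group at this place is known to tolerate a change, since compound 1 with its 2-chlorophenyl and compound 2 with its pyridin-4-yl sit within the scatter of each other. On that basis the step from compound 2 to compound 4 is expected to be small, in either direction, or none beyond the scatter.

For compound 4 the estimate in this assay is 70 nM, with a range from 25 nM to 200 nM. This corresponds to an expected step of a 1.4-fold higher number from compound 2 to compound 4 (0.15 log units; within the scatter).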

Compound 4, half-maximal inhibitory concentration: 1110 nM
Estimate against measurement, compound 4: 16-fold (1.20 log units) below, outside the stated range (above it).
By their numbers in this assay, from the lowest: compounds 2 and 1 (each within the scatter of the next); then compound 4; then compound 3.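

In this assay, with the rest of compound 2 kept, 3-aminophenyl in place of pyridin-4-yl on the aromatic carbon of the five-membered ring gives a 22-fold higher number from compound 2 to compound 4 (1.35 log units; beyond the scatter), a large step. For the compounds shown here, this is the first single-place step, and it shows that inhibition in this assay depends strongly on the aryl group at this position, at least for this exchange; compound 1 and compound 2 differ in more than one place, so the closeness of their numbers could not show this. The change replaces a ring with one hetero atom by a ring of carbon only and also brings in a hydrogen-bond donor, and no evidence at hand bears on the cause of the step.

The compounds shown leave open whether the step follows the loss of the ring nitrogen, the arrival of the amine, or both. An unsubstituted phenyl or a pyridin-3-yl on the same core would separate these readings, and a 4-aminophenyl would test where the amine can sit on the ring.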